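The source may report more compounds than this note shows. Statements on the series, on what has been measured and on what is new or still open speak of the compounds shown alone.

Compound 1 `CCNCC(=O)Nc1cc(OC)ccc1C(=O)c1ccc(OC)c2c1C=CC(C)(C)O2` gives 7890 nM in a functional assay on HCT-8 cells (Homo sapiens) for antiproliferative activity, read by MTT assay, with a stated time of 48 h; on this read-out higher numbers stand for weaker inhibition and lower numbers for stronger inhibition. Compound 2 `COc1ccc(C(=O)c2ccc(OC)c3c2C=CC(C)(C)O3)c(NC(=O)CN(C)C)c1` carries one change against it, (dimethylamino in place of ethylamino on a saturated chain carbon bound to a carbonyl carbon), and in this assay compound 2 gives 5660 nM, a step of a 1.4-fold lower number from compound 1 to compound 2 (0.14 log units; within the scatter). Compound 3 `C=C(c1ccc(OC)cc1NC(=O)CNCC)c1ccc(OC)c2c1C=CC(C)(C)O2` has a different core; how the core of compound 3 differs from the core of compound 1 is not broken down here. In this assay compound 3 gives 3050 nM. Compound 4 `C=C(c1ccc(OC)cc1NC(=O)CN(C)C)c1ccc(OC)c2c1C=CC(C)(C)O2` has not yet been measured; it differs from compound 3 by the same change, (dimethylamino in place of ethylamino on a saturated chain carbon bound to a carbonyl carbon), at the same place. Because a 1.4-fold lower number from compound 1 to compound 2 (0.14 log units; within the scatter) shows that this change moved the number only a little, a step of similar small size is expected from compound 3 to compound 4, a 1.3-fold lower number from compound 3 to compound 4 (0.12 log units; within the scatter). Compound 4 is therefore estimated at about 2300 nM, likely between 1200 nM and 4500 nM.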

Compound 4, half-maximal inhibitory concentration: 1920 nM
Beside the measured number, compound 4's estimate is 1.2-fold (0.08 log units) above it; measured number inside the range.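

In this assay, putting dimethylamino in place of ethylamino gives a 1.6-fold lower number from compound 3 to compound 4 (0.20 log units; within the scatter), and this step can be set beside the one seen on the core of compound 1: the same change on two cores in this assay, a 1.4-fold lower number (0.14 log units; within the scatter) from compound 1 to compound 2 and a 1.6-fold lower number (0.20 log units; within the scatter) from compound 3 to compound 4, 1.1-fold (0.06 log units) apart, within the scatter of two such steps. On these two cores, then, the change behaves alike, and on each it stays too small to separate from ordinary repeat-to-repeat variation. This does not show that the change truly strengthens inhibition on either core, and two cores cannot show that it would carry over in the same way to a third.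

The compounds shown leave open what other groups would do at this place, such as diethylamino, an unsubstituted amine or a carboxylic acid. They also leave open whether a longer chain carrying the amine would give a larger step.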